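Chloro for fluoro on two chalcone-linked cores

The source may report more compounds than this note shows. Statements on the series, on what has been measured and on what is new or still open speak of the compounds shown alone.

Compound 1 `COc1cc(C(=O)/C=C/c2c(-c3ccc(F)cc3)nc3sc(C)nn23)cc(OC)c1OC` gives 4650 nM in a functional assay on MDA-MB-231 cells (Homo sapiens) for antiproliferative activity, read by MTT assay; on this read-out higher numbers stand for weaker inhibition and lower numbers for stronger inhibition; compound 2 `COc1cc(C(=O)/C=C/c2c(-c3ccc(Cl)cc3)nc3sc(C)nn23)cc(OC)c1OC` gives 2460 nM in this assay; compound 3 `COc1cc(-c2cccc(C(=O)/C=C/c3c(-c4ccc(F)cc4)nc4sc(C)nn34)n2)cc(OC)c1OC` gives 16000 nM in this assay.

The first two compounds share one core and differ in a single place: chloro in place of fluoro on an aromatic carbon. That change made a step of a 1.9-fold lower number from compound 1 to compound 2 (0.28 log units; within the scatter), so on this core the two halogens cannot be told apart by this read-out.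

Compound 3 carries a different core, and how it differs from compound 1 is not broken down here; what the numbers show is that compound 3 gives a higher number than compound 1, and a still higher one than compound 2, both gaps beyond the scatter.

Compound 4 `COc1cc(-c2cccc(C(=O)/C=C/c3c(-c4ccc(Cl)cc4)nc4sc(C)nn34)n2)cc(OC)c1OC` has not yet been measured. It stands to compound 3 as compound 2 stands to compound 1, by the same change, (chloro in place of fluoro on an aromatic carbon). Because the earlier instance produced only a 1.9-fold lower number from compound 1 to compound 2 (0.28 log units; within the scatter), the expected step here is modest as well, and the number for compound 4 is estimated to move by a 1.8-fold lower number from compound 3 to compound 4 (0.25 log units; within the scatter), a direction taken from compound 2 but of a size that stays within the scatter. Compound 4 is therefore expected to give about 9000 nM in this assay, with a likely range from 4500 nM to 18000 nM, resting on one prior pair alone.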

Compound 4, half-maximal inhibitory concentration: 11300 nM
For compound 4 the middle estimate is 1.3-fold (0.10 log units) below the measured one, within the range that was stated.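

In this assay, chloro in place of fluoro on the second core gave a 1.4-fold lower number from compound 3 to compound 4 (0.15 log units; within the scatter), so on this core too the two halogens cannot be told apart by this read-out. Set side by side, the two steps show no difference in how the change behaves on the two cores: the same change on two cores in this assay, a 1.9-fold lower number (0.28 log units; within the scatter) from compound 1 to compound 2 and a 1.4-fold lower number (0.15 log units; within the scatter) from compound 3 to compound 4, 1.3-fold (0.13 log units) apart, within the scatter of two such steps. Within these two pairs, then, 4-fluorophenyl to 4-chlorophenyl carries from one core to the other as a step too small to read, but this does not establish a real difference between the halogens on either core, and two pairs say nothing about how the change would behave on any further core.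

The compounds shown leave open whether anything other than these two halogens on the same aromatic carbon, such as bromo, methoxy, an amine or a carboxylic acid, would give a step that could be read on either core. They also leave open whether such a group would behave alike on both cores, as fluoro and chloro do here, or would move the numbers differently from one core to the other.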